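The source may hold more compounds than are shown below. What is called first, only, known or untested is meant among the compounds shown, and "the series" means these compounds.

Compound 1 `COc1ccc(OCCCCCCN2C[C@H](O)[C@@H](O)[C@H](O)[C@H]2CO)cc1`: in an ADME assay on BHK cells (Mesocricetus auratus) for cytotoxicity, read by MTT assay (a lower number here means that less compound is tolerated, a higher number that more compound is tolerated), compound 1 gives > 500000 nM, which is a limit of the assay rather than a number.
Compound 2 `CCC1CCC(OCCCCCCN2C[C@H](O)[C@@H](O)[C@H](O)[C@H]2CO)CC1`: in this assay compound 2 gives 475000 nM.

Compound 2 thus carries the only number shown; the other value is a limit. Among the compounds with values here, the single measured step, an at least 1.0-fold lower number from compound 1 to compound 2 (0.02 log units; that floor lies within the scatter), sits at a floor set by the limit of > 500000 nM in this assay, at which 1 of the 2 values shown sits. Compound 3 `COc1ccccc1OCCCCCCN1C[C@H](O)[C@@H](O)[C@H](O)[C@H]1CO` differs from compound 2 in one place: 2-methoxyphenyl in place of 4-ethylcyclohexyl on an oxygen on a saturated carbon. With only one step shown and that step at the floor, no shift beyond the scatter is expected in this assay; the expected step from compound 2 to compound 3 is a 1.0-fold lower number from compound 2 to compound 3 (0.00 log units; within the scatter). Compound 3 is estimated at 470000 nM, expected between 230000 nM and 900000 nM.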

Compound 3, half-maximal cytotoxic concentration: > 500000 nM
Compound 3 was reported as a limit; the forecaster's own chance of this, stated with the estimate: 45%; at least 1.0-fold (0.02 log units) between middle value and limit.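

With 2-methoxyphenyl in place of 4-ethylcyclohexyl on an oxygen on a saturated carbon, the result is an at least 1.0-fold higher number from compound 2 to compound 3 (0.02 log units; that floor lies within the scatter) in this assay, so this swap shows no change beyond the scatter. Moving the methoxy group from the 4-methoxyphenyl of compound 1 to the 2-methoxyphenyl of compound 3 cannot be read, since both compounds are reported only as limits. Most of the series now sits at the same ceiling: the limit of > 500000 nM in this assay, at which 2 of the 3 values shown sit.

From the compounds shown here alone, the true values of compound 1 and compound 3 remain open. So does whether an amine or a carboxylic acid in place of these rings would give a readable shift.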